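Methyl added to the fused core of a weak series

This account rests on a few compounds, and the source may have more. Where it says the series, first, only, none or still open, it means among the compounds named here.

Within the data shown here, the series so far holds two measured compounds. Compound 1 `N=C(N)N/N=C/c1c(-c2ccsc2)nc2sccn12` and compound 2 `N=C(N)N/N=C/c1c(-c2ccsc2)nc2n1CCS2` carry the same pendant groups and differ only in the core. In a functional assay on cells (Cancer cell lines, Homo sapiens) for inhibition (on this read-out lower numbers stand for stronger inhibition of growth and higher numbers for weaker inhibition of growth), compound 1 gives 14100 nM and compound 2 gives 22900 nM. These two numbers sit within the usual scatter of each other, so compound 1 cannot be set apart from compound 2 on this read-out. Among the measured compounds shown here, no pair of measured compounds differs in a single place, so nothing measured speaks directly to a single substituent change.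

Compound 3 `Cc1cn2c(/C=N/NC(=N)N)c(-c3ccsc3)nc2s1` is the next compound to be measured. Compared with compound 1 it carries methyl in place of hydrogen on an aromatic carbon. One carbon added on the core, with no donor or acceptor and no charge, is a small change, and with nothing measured to guide it the expectation is no step beyond the scatter, in either direction. The estimate for compound 3 is 12000 nM with a range of 5000 nM to 30000 nM. The expected step of a 1.2-fold lower number from compound 1 to compound 3 (0.07 log units; within the scatter) stays within the scatter.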

Compound 3, concentration for 50% growth inhibition: 5370 nM
Beside the measured number, compound 3's estimate is 2.2-fold (0.35 log units) above it; low and high end bracket the measured number.
By their numbers in this assay, from the lowest: compound 3; then compounds 1 and 2 (each within the scatter of the next).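

This position on the core, an aromatic carbon next to the ring sulfur, is not silent: in this assay, methyl in place of hydrogen gives a 2.6-fold lower number from compound 1 to compound 3 (0.42 log units; beyond the scatter). Among these compounds, this is the only single-place change so far, and it shows that one added carbon, with no hydrogen-bond donors, no hydrogen-bond acceptors and no net charge, can move this read-out towards stronger inhibition of growth, although the step is modest. Nothing at hand accounts for the step, so its origin remains unexplained.

A single substituent at a single position cannot show whether the step belongs to methyl specifically or would also appear with a larger or different group on the same carbon, such as an ethyl group, a chlorine atom, a methoxy group or an amine. The data also leave open whether this methyl would give a similar step if the other parts of compound 3 were changed, since the pendant groups have stayed the same throughout.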